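This account rests on a few compounds, and the source may have more. Where it says the series, first, only, none or still open, it means among the compounds named here.

In a functional assay on MGC-803 cells (Homo sapiens) for inhibition, read by MTT assay, with a stated time of 72 h (on this read-out higher numbers stand for weaker inhibition and lower numbers for stronger inhibition), two compounds have been measured so far. Compound 1 `C=CC(=O)Nc1cccc(NC(=O)CSc2nc(Nc3ccccc3Br)c3ccccc3n2)c1` gives 12800 nM, and compound 2 `C=CC(=O)Nc1cccc(NC(=O)CSc2nc(Nc3cccc(Cl)c3)c3ccccc3n2)c1` gives 7830 nM. The two differ in one place, the ring attached to a nitrogen of the shared core: a 1.6-fold lower number from compound 1 to compound 2 (0.21 log units; within the scatter). Compound 2 thus holds the lower of the two numbers, but the gap to compound 1 lies within the scatter, so the two cannot be told apart on this read-out. Compound 3 `C=CC(=O)Nc1cccc(NC(=O)CSc2nc(Nc3cccc(Br)c3)c3ccccc3n2)c1` has not yet been measured. It differs from compound 2 in one place: bromo in place of chloro on an aromatic carbon. Going by the values given here, the only measured step that bears on this change is the one from compound 1 to compound 2, which also exchanged bromo for chloro, though the position on the ring moved at the same time, and that step stayed within the scatter. Among the compounds with values here, no measured step isolates the exchange of these two groups alone. The expected step is accordingly no larger than the scatter, in no clear direction: a 1.1-fold lower number from compound 2 to compound 3 (0.05 log units; within the scatter). Compound 3 is estimated at 7000 nM, within a range from 3000 nM to 18000 nM.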

Compound 3, half-maximal inhibitory concentration: 11900 nM
For compound 3 the middle estimate is 1.7-fold (0.23 log units) below the measured one; the measured number falls inside the stated range.
By their numbers in this assay, from the lowest: compounds 2, 3 and 1 (each within the scatter of the next).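

In this assay the exchange of chloro for bromo on this aromatic carbon can now be read on its own, with nothing else on the molecule altered (a 1.5-fold higher number from compound 2 to compound 3 (0.18 log units; within the scatter)). The place of the halogen can also be read alone, since 3-bromophenyl replaces 2-bromophenyl while the halogen stays bromo (a 1.1-fold lower number from compound 1 to compound 3 (0.03 log units; within the scatter)), whereas the earlier step changed the halogen and its place together, so neither change could be judged separately; now each of the two, taken singly, stays within the scatter, and compound 1, compound 2 and compound 3 cannot be told apart on this read-out. Nothing available explains why these numbers lie so close together.

As far as these compounds go, all three compounds carry a single halogen on this ring, so it remains open whether a group of another kind there, such as a methoxy group, an amine or a carboxylic acid, would give a step beyond the scatter. The compounds shown also share everything else, leaving open how much the number depends on the shared core, the sulfur-containing linker or the acrylamide end.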